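The compounds below may be only part of what the source reports. "The series", "measured", "known", "first", "only" and "open" are said of these compounds alone.

Three compounds share one core and differ only in the group attached to the carbonyl carbon on the ring nitrogen. Compound 1 `Cc1nc(S(C)(=O)=O)ccc1Oc1ncnc(OC2CCN(C(=O)OC(C)(C)C#N)CC2)c1F` gives 92.9 nM in a functional assay on isolated protein for inhibition of Glucose-dependent insulinotropic receptor (Homo sapiens), read by HTRF and cAMP accumulation; on this read-out higher numbers stand for an effect only at larger amounts of compound and lower numbers for an effect already at smaller amounts. Compound 2 `Cc1nc(S(C)(=O)=O)ccc1Oc1ncnc(OC2CCN(C(=O)SC(C)(C)C)CC2)c1F` gives 4.83 nM in this assay, a step of a 19-fold lower number from compound 1 to compound 2 (1.28 log units; beyond the scatter). Compound 3 `Cc1nc(S(C)(=O)=O)ccc1Oc1ncnc(OC2CCN(C(=O)SC3(C)CC3)CC2)c1F` gives 13.2 nM in this assay; on this set it stands second highest of the three numbers, with a 7.0-fold lower number from compound 1 to compound 3 (0.85 log units; beyond the scatter) and a 2.7-fold higher number from compound 2 to compound 3 (0.44 log units; beyond the scatter).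

Compound 4 `Cc1nc(S(C)(=O)=O)ccc1Oc1ncnc(OC2CCN(C(=O)C(C)(F)F)CC2)c1F` carries the change (a group of 4 heavy atoms (2 carbon, 2 fluorine; no ring) in place of a group of 5 heavy atoms (4 carbon, 1 sulfur; one three-membered non-aromatic ring of carbon only), on a carbonyl carbon). For the measured compounds named here, no measured step removes the sulfur entirely or brings in fluorine, so the evidence bears only loosely on it. Going by the values given here, the steps so far show that the group on this carbonyl carbon matters strongly, as in a 19-fold lower number from compound 1 to compound 2 (1.28 log units; beyond the scatter), and that exchanging one sulfur-bearing group for another moves the number modestly, as in a 2.7-fold higher number from compound 2 to compound 3 (0.44 log units; beyond the scatter). A change that removes the sulfur and the ring altogether is expected to move the number more than the latter, and the direction is judged from compound 1, whose sulfur-free group gives 92.9 nM, as a step toward a higher number. Compound 4 is therefore expected to show a 3.0-fold higher number from compound 3 to compound 4 (0.48 log units; beyond the scatter), with an estimated 40 nM in this assay, within a range from 10 nM to 200 nM.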

Compound 4, half-maximal effective concentration: 37 nM
Compound 4: middle estimate off by 1.1-fold (0.03 log units), on the high side; measured number inside the range.
By their numbers in this assay, from the lowest: compound 2; then compound 3; then compound 4; then compound 1.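

In this assay, the carbonyl carbon on the amide-type nitrogen does not need sulfur to keep a number well below that of the group with the nitrile: with 1,1-difluoroethyl there, which holds neither sulfur nor a ring, the result is a 2.5-fold lower number from compound 1 to compound 4 (0.40 log units; beyond the scatter). Both sulfur-bearing groups still do better, however, with a 2.8-fold higher number from compound 3 to compound 4 (0.45 log units; beyond the scatter) and a 7.7-fold higher number from compound 2 to compound 4 (0.88 log units; beyond the scatter), so across these four compounds the two groups with sulfur give lower numbers than the two without it, and no compound shown goes against this. Nothing measured here explains this order, and no separate data on these groups accompany the numbers.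

Going by these compounds, what plain ethyl would give on this carbonyl carbon stays open, so the share of the two fluorine atoms in the number of compound 4 cannot be separated from that of the carbon chain that carries them. Equally open, on these data alone, is how an amine on this carbonyl carbon, or a chain longer than 1,1-difluoroethyl, would compare with the (tert-butyl)sulfanyl group of compound 2.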